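Cytotoxicity of Three Iminothiazolidinones and a Nitro Analogue

The source may hold more compounds than are shown below. What is called first, only, known or untested is meant among the compounds shown, and "the series" means these compounds.

Measured compounds:
Compound 1, `N=C1S/C(=C\c2ccc(OCc3ccccc3)cc2)C(=O)N1c1ccc(Br)cc1`, gives 7.83%.
Compound 2, `N=C1S/C(=C\c2ccc(OCc3ccccc3)cc2)C(=O)N1c1ccc(Cl)cc1`, gives 16.4%.
Compound 3, `N=C1S/C(=C\c2ccc(OCc3ccccc3)cc2)C(=O)N1c1ccc(F)cc1`, gives 10.5%.

These three compounds were tested in an ADME assay on RAW264.7 cells (Mus musculus) for cytotoxicity, read by MTT assay, with a stated time of 48 h, tested at 50 uM; a higher number here means more inhibition at the concentration tested (going by the name of the read-out), a lower number less inhibition. Compound 3 holds the second highest of the three numbers; its nearest neighbour is compound 1, and a number 2.7 percentage points higher from compound 1 to compound 3 (within the scatter). Its furthest neighbour is compound 2, and a number 5.9 percentage points lower from compound 2 to compound 3 (within the scatter). The third comparison, a number 8.6 percentage points higher from compound 1 to compound 2 (within the scatter), completes the picture: all three halogen variants sit close together, and none of the steps between them goes beyond the scatter.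

Compound 4, `N=C1S/C(=C\c2ccc(OCc3ccccc3)cc2)C(=O)N1c1ccccc1[N+](=O)[O-]`, has not yet been measured. It differs from compound 3 by 2-nitrophenyl in place of 4-fluorophenyl on an amide-type nitrogen in a ring. Going by the values given here, none of the measured steps involves a nitro group, so no direct comparison for this change exists; the halogen steps bear on it only by showing that exchanging one group for another on this ring left this assay unchanged within the scatter in every case.

Compound 4 is therefore expected to give 12%, with a range from 0% to 30%. The step this implies, a number 1.5 percentage points higher from compound 3 to compound 4 (within the scatter), is expected to lie within the scatter.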

Compound 4, a percentage reported as inhibition, at one concentration (the size of the read-out at that concentration, not a potency): 24.4%
Compound 4: middle estimate off by 12.4 percentage points, on the low side, and the stated range covers the measured number.
By their numbers in this assay, from the lowest: compounds 1, 3, 2 and 4 (each within the scatter of the next, the first and the last beyond it).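

In this assay the group on the amide-type nitrogen in a ring proves able to shift the number beyond the scatter, which no halogen exchange had done: the record gives a number 13.9 percentage points higher from compound 3 to compound 4 (beyond the scatter) and also a number 16.6 percentage points higher from compound 1 to compound 4 (beyond the scatter) for the same kind of change. The picture is not uniform, and compound 2 goes against any claim that 2-nitrophenyl stands apart from all the halogen-bearing phenyl groups, for the record there gives a number 8 percentage points higher from compound 2 to compound 4 (within the scatter) and so leaves that pair unresolved. Nothing available bears on what lies behind these steps.

The change from 4-fluorophenyl to 2-nitrophenyl alters both the group carried on the aromatic ring and where it is carried, and the compounds shown do not separate these two differences. As far as these compounds go, how this assay would respond to an amine or a carboxylic acid on this aromatic ring, or to a phenyl group carrying nothing at all, also remains open.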